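This account rests on a few compounds, and the source may have more. Where it says the series, first, only, none or still open, it means among the compounds named here.

Measured in a functional assay on HaCaT cells (Homo sapiens) for antiproliferative activity, read by sulforhodamine B assay, with a stated time of 3 days; on this read-out higher numbers stand for weaker inhibition and lower numbers for stronger inhibition:
Compound 1 `COC(=O)c1cc(CCc2cccc(OC)c2)ccc1O`: 37000 nM
Compound 2 `COC(=O)c1cc(CCc2cc(OC)ccc2C(C)=O)ccc1O`: 41 nM

Compound 2, at 41 nM, holds the lower of these two numbers, which makes it the stronger inhibitor of the pair. Going by the values given here, the single measured step, a 900-fold lower number from compound 1 to compound 2 (2.96 log units; beyond the scatter), is large and lies well beyond the scatter. It came from acetyl in place of hydrogen on an aromatic carbon, so that one spot on the molecule clearly matters in this assay.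

Compound 3 `CCc1ccc(OC)cc1CCc1ccc(O)c(C(=O)OC)c1` has not yet been measured. It changes that same spot, with ethyl in place of acetyl on an aromatic carbon. Ethyl keeps a group at this position but lacks the carbonyl of acetyl. Among the compounds with values here, no measured compound shows what ethyl does here, so the only guide is the step of a 900-fold lower number from compound 1 to compound 2 (2.96 log units; beyond the scatter), and a partial return along it seems the most likely outcome. The expected change is a 24-fold higher number from compound 2 to compound 3 (1.39 log units; beyond the scatter), a clear move to a higher number, though the size is uncertain. For compound 3 the estimated value is 1000 nM, with an expected range from 100 nM to 12000 nM.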

Compound 3, half-maximal inhibitory concentration: 130 nM
Compound 3: middle estimate off by 7.7-fold (0.89 log units), on the high side; the measured number falls inside the stated range.
By their numbers in this assay, from the lowest: compound 2; then compound 3; then compound 1.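

Most of the gain at this position survives without the carbonyl: ethyl in place of hydrogen still gives a 280-fold lower number from compound 1 to compound 3 (2.45 log units; beyond the scatter) and so accounts for the larger part of the effect first seen with acetyl. Going from acetyl to ethyl gives only a 3.2-fold higher number from compound 2 to compound 3 (0.50 log units; beyond the scatter) even though this step removes the carbonyl oxygen, the one hydrogen-bond acceptor counted in the change, so a group at this spot with neither that oxygen nor that acceptor can still give a much lower number than hydrogen, while acetyl keeps a real but modest edge over ethyl. No measurement shown here bears on why either group lowers the number.

The compounds shown leave open how the number responds to other groups at this spot, such as a single methyl, a longer chain like propyl, an amine or a carboxylic acid. They also leave open whether the order of hydrogen, ethyl and acetyl would hold if the methoxy group or the methyl ester elsewhere on the shared core were changed.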